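The source may report more compounds than this note shows. Statements on the series, on what has been measured and on what is new or still open speak of the compounds shown alone.

Of the compounds shown here, three sharing one core have been measured in a functional assay on HepG2 cells (Homo sapiens) for antiproliferative activity, read by MTT assay, with a stated time of 48 h; on this read-out lower numbers stand for stronger inhibition and higher numbers for weaker inhibition. Compound 1 `O=C(Nc1cccc(CNc2nccnc2Cl)c1)Nc1ccc(Cl)cc1Br` gives 6720 nM. Compound 2 `O=C(Nc1cccc(CNc2nccnc2Cl)c1)Nc1cccc(C(F)(F)F)c1` gives 6210 nM, and compound 3 `O=C(Nc1ccc(C(F)(F)F)cc1)Nc1cccc(CNc2nccnc2Cl)c1` gives 5050 nM. Compound 1 has the highest of these three numbers, yet its gaps to compound 2 and to compound 3 both fall within the usual scatter, so the three cannot be told apart. Compound 4 `CCc1ccccc1NC(=O)Nc1cccc(CNc2nccnc2Cl)c1` is not yet measured. It differs from compound 1 in one place: 2-ethylphenyl in place of 2-bromo-4-chlorophenyl on an amide-type nitrogen. Going by the values given here, no two measured compounds differ by a single change, so no measured step guides this one. Compound 1 and compound 3 carry different groups on that amide-type nitrogen yet lie within the scatter of each other. Compound 4 is therefore expected to show a step of a 1.0-fold higher number from compound 1 to compound 4 (0.02 log units; within the scatter), not beyond the scatter. Compound 4 is estimated at 7000 nM, with a range from 3500 nM to 15000 nM.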

Compound 4, half-maximal inhibitory concentration: 7860 nM
Beside the measured number, compound 4's estimate is 1.1-fold (0.05 log units) below it, and the stated range covers the measured number.
By their numbers in this assay, from the lowest: compounds 3, 2, 1 and 4 (each within the scatter of the next).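

Going by these compounds alone, this is the first comparison in the set that changes only one place: in this assay, 2-ethylphenyl in place of 2-bromo-4-chlorophenyl on the amide-type nitrogen gives a 1.2-fold higher number from compound 1 to compound 4 (0.07 log units; within the scatter). At this position, then, a ring carrying no chlorine or bromine reads the same as the halogenated one, as far as the scatter allows. Nothing available explains why the two groups read alike. Still open, on these data alone, is whether a ring bearing an amine or a carboxylic acid, or a chain longer than ethyl, would move the number beyond the scatter.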